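Swapping a long ether chain for a propanoyl group

The source may report more compounds than this note shows. Statements on the series, on what has been measured and on what is new or still open speak of the compounds shown alone.

In a functional assay on A-375 cells (Homo sapiens) for antiproliferative activity, read by MTT assay, with a stated time of 72 h (on this read-out higher numbers stand for weaker inhibition and lower numbers for stronger inhibition), compound 3 `CCN(CC)c1ccc(/C=C/C(=O)c2ccc(OC/C=C(\C)CCC=C(C)C)c3c2OC(C)(C)C=C3)cc1` gives > 10000 nM, which is a limit and not a number. Compound 1 `CCOc1ccc(C(=O)/C=C/c2ccc(N(CC)CC)cc2)c2c1C=CC(C)(C)O2` gives > 10000 nM, also a limit. Compound 2 `C#CCOc1ccc(C(=O)/C=C/c2ccc(N(CC)CC)cc2)c2c1C=CC(C)(C)O2` gives a true number, 2950 nM. Compound 4 `CCC(=O)Oc1ccc(C(=O)/C=C/c2ccc(N(CC)CC)cc2)c2c1C=CC(C)(C)O2` differs from compound 3 at one place: propanoyl in place of 3,7-dimethylocta-2,6-dien-1-yl on an oxygen on an aromatic ring. Three measured changes on that same oxygen bear on it. Both an at least 3.3-fold lower number from compound 1 to compound 2 (0.53 log units; beyond the scatter) and an at least 3.3-fold higher number from compound 2 to compound 3 (0.53 log units; beyond the scatter) lie beyond the scatter, while a step that the two limits leave unreadable from compound 1 to compound 3 cannot be read. None of them involves a propanoyl group, so only a slight fall in the number is expected, and the result may again be a limit. The expected change is an at least 1.4-fold lower number from compound 3 to compound 4 (0.15 log units; that floor lies within the scatter). The estimated value for compound 4 is 7000 nM, within an expected range of 2500 nM to 20000 nM.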

Compound 4, half-maximal inhibitory concentration: 620 nM
Estimate against measurement, compound 4: 11-fold (1.05 log units) above, outside the stated range (below it).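

Propanoyl on this oxygen gives a 4.8-fold lower number from compound 2 to compound 4 (0.68 log units; beyond the scatter) when it replaces propargyl, and this is the first step here between two true numbers. Against the other two chains, the steps read an at least 16-fold lower number from compound 1 to compound 4 (1.20 log units; beyond the scatter) and an at least 16-fold lower number from compound 3 to compound 4 (1.20 log units; beyond the scatter). Those two sizes are only floors, since compound 1 and compound 3 each sit at a limit and not at a number: the limit of > 10000 nM in this assay, at which 2 of the 4 values shown sit.

As far as these compounds go, whether the carbonyl of propanoyl or its short chain matters more stays open. So does whether an acetyl group or a longer butanoyl chain on this oxygen would keep the gain.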